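The source may report more compounds than this note shows. Statements on the series, on what has been measured and on what is new or still open speak of the compounds shown alone.

Measured so far:
- compound 1 `CCCOc1cccc(-c2[nH]c3cc(OC)ccc3c(=O)c2C(=O)OCC)c1`: in an ADME assay on HEK293 cells (Homo sapiens) for cytotoxicity, read by luminescence, with a stated time of 72 h (a lower number here means that less compound is needed, a higher number that more compound is needed for the effect), compound 1 gives > 22000 nM, a limit of the assay.
- compound 2 `CCOC(=O)c1c(-c2cccc(Oc3ccccc3)c2)[nH]c2cc(OC)ccc2c1=O`: compound 2 gives > 22000 nM, likewise a limit.

Compound 1 therefore stands only at a limit in this assay, the position described by the limit of > 22000 nM in this assay, at which 2 of the 2 values shown sit. Compound 3 `CCOC(=O)c1c(-c2cccc(Cl)c2)[nH]c2cc(OC)ccc2c1=O` differs from compound 1 by chloro in place of propoxy on an aromatic carbon. For the measured compounds named here, the one measured step at this oxygen-bearing position, a step that the two limits leave unreadable from compound 1 to compound 2, gives no readable size and concerns a different entering group, so no direction can be taken from it. Compound 3 is expected to sit at 30000 nM, between 12000 nM and 80000 nM. The step this estimate implies, a step that the limit leaves unreadable from compound 1 to compound 3, is expected to stay within the scatter, most likely again reported only as a limit.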

Compound 3, half-maximal effective concentration: > 22000 nM
Compound 3 was reported as a limit; the forecaster's own chance of this, stated with the estimate: 80%; the middle value is on the limit's open side.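

Compound 3 joins compound 1 and compound 2 at a limit, so no step among the three can be read: the limit of > 22000 nM in this assay, at which 3 of the 3 values shown sit.

Whether chloro, propoxy and phenoxy differ at all in this assay, and at what concentration any of these compounds reaches half-maximal effect, stays open.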